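The source may report more compounds than this note shows. Statements on the series, on what has been measured and on what is new or still open speak of the compounds shown alone.

Measured compounds:
- compound 1 `CC(C)(C)c1cc(N)c2cc(NC(=O)/C=C/c3ccc(C(F)(F)F)cc3)ccc2n1`, an assay on isolated protein for displacement of a labelled ligand from melanin-concentrating hormone receptor 1 (Homo sapiens) (on this read-out lower numbers stand for stronger inhibition and higher numbers for weaker inhibition), 0.3 nM
- compound 2 `CCc1cc(N)c2cc(NC(=O)/C=C/c3ccc(C(F)(F)F)cc3)ccc2n1`, this assay 1.2 nM
- compound 3 `CC(C)c1cc(N)c2cc(NC(=O)/C=C/c3ccc(C(F)(F)F)cc3)ccc2n1`, this assay 2.1 nM

Compound 3 gives the highest number of the three. Its nearest neighbour is compound 2, and the gap a 1.8-fold higher number from compound 2 to compound 3 (0.24 log units; within the scatter) is within the scatter, so the two cannot be ordered. Against compound 1 the gap a 7.0-fold higher number from compound 1 to compound 3 (0.85 log units; beyond the scatter) is beyond the scatter, so compound 1 stands clearly lower.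

Compound 4 `Nc1cc(-c2ccccc2)nc2ccc(NC(=O)/C=C/c3ccc(C(F)(F)F)cc3)cc12` is the next member. The change from compound 3 is phenyl in place of isopropyl on an aromatic carbon. Among the compounds with values here, no measured step exchanges the alkyl group at this position for a ring, so the nearest guidance comes from the alkyl-to-alkyl exchanges at the same carbon: a 4.0-fold higher number from compound 1 to compound 2 (0.60 log units; beyond the scatter), a 7.0-fold higher number from compound 1 to compound 3 (0.85 log units; beyond the scatter) and a 1.8-fold higher number from compound 2 to compound 3 (0.24 log units; within the scatter). These show that the group at this position moves the number, with the largest group in the set giving the lowest number, but the three groups span only a narrow range and nothing here covers an aromatic ring.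

For compound 4 the expected step is therefore a 1.4-fold lower number from compound 3 to compound 4 (0.15 log units; within the scatter), a modest move towards lower numbers that may well fall within the scatter, with wide uncertainty in both directions. The estimate for compound 4 in this assay is 1.5 nM, with a range from 0.3 nM to 8 nM.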

Compound 4, half-maximal inhibitory concentration: 18.5 nM
For compound 4 the middle estimate is 12-fold (1.09 log units) below the measured one; measured number outside the range, above it.
By their numbers in this assay, from the lowest: compound 1; then compounds 2 and 3 (each within the scatter of the next); then compound 4.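

In this assay, phenyl on this aromatic carbon next to the ring nitrogen gives the highest number of the four compounds, with an 8.8-fold higher number from compound 3 to compound 4 (0.94 log units; beyond the scatter), a 15-fold higher number from compound 2 to compound 4 (1.19 log units; beyond the scatter) and a 62-fold higher number from compound 1 to compound 4 (1.79 log units; beyond the scatter). The earlier reading, in which tert-butyl as the largest alkyl group gave the lowest number, does not extend to an aromatic ring: phenyl, with 6 heavy atoms against 3 for isopropyl, raises the number, so heavy-atom count alone does not order the groups at this position. No supporting data bear on why the number rises with this exchange.

The compounds shown leave open whether the rise goes with aromatic rings in general or with phenyl alone; a saturated cyclohexyl ring, a pyridyl ring or a phenyl carrying a fluorine would help separate these cases. Also open, from the compounds shown here alone, is how far the low numbers extend among other non-aromatic groups, such as cyclopropyl or a longer chain like n-butyl, and whether any of them matches tert-butyl.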